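This account rests on a few compounds, and the source may have more. Where it says the series, first, only, none or still open, it means among the compounds named here.

Among the compounds with values here, compound 1 `CCCCNc1nc(N)nc(C)c1CCCC(C)(C)O` gives 1220 nM in an assay on HEK293 cells for agonist activity at Toll-like receptor 8 (Homo sapiens), read by spectrophotometry (on this read-out lower numbers stand for an effect already at smaller amounts and higher numbers for an effect only at larger amounts of compound), the higher of the two numbers measured so far; compound 2 `CCCCNc1nc(N)nc(C)c1CCCCCc1ccccc1` gives 830 nM, and the step of a 1.5-fold lower number from compound 1 to compound 2 (0.17 log units; within the scatter) lies within the scatter. Compound 3 `CCCCNc1nc(N)nc(C)c1C` differs from compound 1 by hydrogen in place of 3-hydroxy-3-methylbutyl on a saturated chain carbon bound to an aromatic carbon. Within the data shown here, the one measured step swaps one chain end for another and keeps the chain, so it says little about removing the chain entirely, and no step of that kind is known here. Expecting the number to rise, with wide uncertainty, the estimate for compound 3 is 5000 nM, between 1000 nM and 30000 nM, a step of a 4.1-fold higher number from compound 1 to compound 3 (0.61 log units; beyond the scatter).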

Compound 3, half-maximal effective concentration: 3280 nM
For compound 3 the middle estimate is 1.5-fold (0.18 log units) above the measured one; measured number inside the range.
By their numbers in this assay, from the lowest: compounds 2 and 1 (each within the scatter of the next); then compound 3.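

Replacing 3-hydroxy-3-methylbutyl with hydrogen on a saturated chain carbon bound to an aromatic carbon gives, in this assay, a 2.7-fold higher number from compound 1 to compound 3 (0.43 log units; beyond the scatter). So the number at this position does respond to the chain, though only modestly: even without it, compound 3 gives 3280 nM, a number of the same general order as those of the chain-bearing compounds. Nothing measured here gives a reason for this rise. Still open, from the compounds shown here alone, is how the number would respond to a shorter chain such as ethyl, or to a chain ending in an amine or a carboxylic acid.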